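Cytotoxicity notes: cyclopropylamino analogue of compound 1

A few compounds are considered here, and "the series" means these few. Any claim that something is new, unique, unknown or untested is made for them only; others in the source may bear on it.

Among the measured compounds shown here, compound 1 `CNc1cc(Oc2c(OC)cc3cc(C#N)ccc3c2OC)nc(Nc2ccc(C#N)cc2)n1` is the only compound with a full number in an ADME assay on MT4 cells (Homo sapiens) for cytotoxicity, read by MTT assay, with a stated time of 5 days; on this read-out lower numbers stand for higher toxicity in this test and higher numbers for lower toxicity in this test: compound 1 gives 239000 nM, the single value read out as a number. Compound 2 `CCC(C)Nc1cc(Oc2c(OC)cc3cc(C#N)ccc3c2OC)nc(Nc2ccc(C#N)cc2)n1` reaches only the limit > 125000 nM in this assay. The step that the limit leaves unreadable from compound 1 to compound 2 therefore cannot be sized; as the limit of > 125000 nM in this assay, at which 1 of the 2 values shown sits, shows, one of the two values rests at that limit. Compound 3 `COc1cc2cc(C#N)ccc2c(OC)c1Oc1cc(NC2CC2)nc(Nc2ccc(C#N)cc2)n1` carries cyclopropyl in place of methyl on a nitrogen on an aromatic ring. For the measured compounds named here, no measured step reads cleanly, so no shift beyond the scatter is expected in this assay. Compound 3 is expected near 200000 nM, within 80000 nM to 500000 nM, an estimated step of a 1.2-fold lower number from compound 1 to compound 3 (0.08 log units; within the scatter).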

Compound 3, half-maximal cytotoxic concentration: > 125000 nM
Compound 3: only a limit was reported; the forecaster's own chance of this, stated with the estimate: 40%; the middle value does not contradict the limit.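

No step from compound 3 to compound 1 or compound 2 can be read in this assay: the limit of > 125000 nM in this assay, at which 2 of the 3 values shown sit.

As far as these compounds go, the size of the methylamino to cyclopropylamino change stays open, as does any order between compound 2 and compound 3.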